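Swapping a sulfoamino-pyrrolidine for a diethylamino group

The source may report more compounds than this note shows. Statements on the series, on what has been measured and on what is new or still open speak of the compounds shown alone.

Compound 1 `O=C(CCc1ccc(C(F)(F)F)cc1)Nc1ccc2nc(N3CCC(NS(=O)(=O)O)C3)ccc2c1` is the strongest of the three compounds measured here. In a functional assay on HEK293 cells for activation of melanin-concentrating hormone receptor 1 (Rattus norvegicus), read by inositol phosphate accumulation (a higher number here means that more compound is needed for the effect, a lower number that less compound is needed), compound 1 gives 50 nM, compound 2 `NC1CCN(c2ccc3cc(NC(=O)CCc4ccc(C(F)(F)F)cc4)ccc3n2)C1` gives 200 nM, and compound 3 `O=C(CCc1ccc(C(F)(F)F)cc1)Nc1ccc2nc(N3CCCCCC3)ccc2c1` gives 1800 nM. The steps among them are all beyond the scatter: a 4.0-fold higher number from compound 1 to compound 2 (0.60 log units; beyond the scatter), a 36-fold higher number from compound 1 to compound 3 (1.56 log units; beyond the scatter) and a 9.0-fold higher number from compound 2 to compound 3 (0.95 log units; beyond the scatter).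

Compound 4 `CCN(CC)c1ccc2cc(NC(=O)CCc3ccc(C(F)(F)F)cc3)ccc2n1` differs from compound 1 in one place: diethylamino in place of 3-(sulfoamino)pyrrolidin-1-yl on an aromatic carbon. The group that enters is placed on an aromatic carbon of a six-membered aromatic ring with one nitrogen, next to the ring nitrogen, as the group that leaves was.

For the measured compounds named here, the step that bears most directly on this change is the one from compound 1 to compound 3, in which a ring without hydrogen-bond donors replaced the 3-(sulfoamino)pyrrolidin-1-yl group and the number rose by a large margin, a 36-fold higher number from compound 1 to compound 3 (1.56 log units; beyond the scatter). The step from compound 1 to compound 2, a 4.0-fold higher number from compound 1 to compound 2 (0.60 log units; beyond the scatter), shows that even removing the sulfo group alone costs potency. Diethylamino likewise carries no hydrogen-bond donor and no ring, so a large rise in this assay is expected for compound 4, roughly a 50-fold higher number from compound 1 to compound 4 (1.70 log units; beyond the scatter). Compound 4 is therefore estimated at 2500 nM, with a likely range from 600 nM to 10000 nM.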

Compound 4, half-maximal effective concentration: 830 nM
The estimate for compound 4 lay 3.0-fold (0.48 log units) above the measured number; the measured number falls inside the stated range.
By their numbers in this assay, from the lowest: compound 1; then compound 2; then compound 4; then compound 3.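

Diethylamino does not match either pyrrolidine group at this position: there is a 17-fold higher number from compound 1 to compound 4 (1.22 log units; beyond the scatter) against 3-(sulfoamino)pyrrolidin-1-yl and a 4.2-fold higher number from compound 2 to compound 4 (0.62 log units; beyond the scatter) against 3-aminopyrrolidin-1-yl in this assay among these compounds. For the compounds shown here, what the earlier compounds could not show is that replacements lacking the substituted pyrrolidine are not all equal here, for there is a 2.2-fold lower number from compound 3 to compound 4 (0.34 log units; beyond the scatter) on going from azepan-1-yl to diethylamino, a modest step but one beyond the scatter. At this aromatic carbon next to the ring nitrogen, the open diethylamino group with no ring therefore ranks ahead of the azepan-1-yl ring and behind both substituted pyrrolidines, and nothing shown here gives a measured reason for that order.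

The compounds shown leave open how a carboxylic acid or a methanesulfonamide on the pyrrolidine would compare with the sulfoamino group of compound 1. They also leave open whether a dimethylamino group, or a longer chain as in dipropylamino, would stand closer to diethylamino or to azepan-1-yl in this series.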